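Changing the amide-side group of compound 1

This account rests on a few compounds, and the source may have more. Where it says the series, first, only, none or still open, it means among the compounds named here.

Compound 1 `CC1=C(/C=C/C(C)=C/C=C/C(C)=C\C(=O)NCc2ccc(F)cc2)C(C)(C)CCC1n1ccnc1`: 5500 nM
Compound 2 `CC1=C(/C=C/C(C)=C/C=C/C(C)=C\C(=O)NCc2ccc(O)cc2)C(C)(C)CCC1n1ccnc1`: 2450 nM
Compound 3 `CC1=C(/C=C/C(C)=C/C=C/C(C)=C\C(=O)NCc2cccc(F)c2)C(C)(C)CCC1n1ccnc1`: 4240 nM

In a functional assay on SK-BR-3 cells (Homo sapiens) for inhibition, read by MTT assay (a lower number here means a stronger inhibitor of growth, a higher number a weaker inhibitor of growth), compound 1 gives the highest of the three numbers. Compound 3 stays within the scatter of it (a 1.3-fold lower number from compound 1 to compound 3 (0.11 log units; within the scatter)), whereas compound 2 lies beyond it (a 2.2-fold lower number from compound 1 to compound 2 (0.35 log units; beyond the scatter)). Compound 4 `CC1=C(/C=C/C(C)=C/C=C/C(C)=C\C(=O)Nc2ccccc2O)C(C)(C)CCC1n1ccnc1` differs from compound 1 in one place: 2-hydroxyphenyl in place of 4-fluorobenzyl on an amide-type nitrogen. For the measured compounds named here, the only measured step that bears on this is the one where hydroxy entered in place of fluoro, a 2.2-fold lower number from compound 1 to compound 2 (0.35 log units; beyond the scatter); no measured pair covers a ring bound directly to the amide-type nitrogen instead of through a saturated chain carbon. A modest lower number is therefore expected, with wide uncertainty. Compound 4 is estimated at 3500 nM, between 1200 nM and 10000 nM. That expected step is a 1.6-fold lower number from compound 1 to compound 4 (0.20 log units; within the scatter).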

Compound 4, concentration for 50% growth inhibition: 3890 nM
Estimate against measurement, compound 4: 1.1-fold (0.05 log units) below, within the range that was stated.
By their numbers in this assay, from the lowest: compounds 2, 4, 3 and 1 (each within the scatter of the next, the first and the last beyond it).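

In this assay, a ring bound directly to the amide-type nitrogen, as 2-hydroxyphenyl, proves indistinguishable from the benzyl groups: all three steps lie within the scatter (a 1.4-fold lower number from compound 1 to compound 4 (0.15 log units; within the scatter); a 1.1-fold lower number from compound 3 to compound 4 (0.04 log units; within the scatter); a 1.6-fold higher number from compound 2 to compound 4 (0.20 log units; within the scatter)). Compound 4 thus sits within the scatter of compound 1 and of compound 2, though those two lie beyond the scatter of each other. Nothing available explains this result. Left open is whether an unsubstituted phenyl, or a 2-fluorophenyl, on that nitrogen would behave like compound 4. Also open, on these data alone, is whether an amine or a carboxylic acid on that ring would move the number beyond the scatter.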